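Replacing methylamino with 2,6-dimethylmorpholin-4-yl on a carbonyl carbon

This account rests on a few compounds, and the source may have more. Where it says the series, first, only, none or still open, it means among the compounds named here.

Measured in a functional assay on KETR3 cells (Homo sapiens) for inhibition, read by MTT assay, with a stated time of 120 h; a higher number here means a weaker inhibitor, a lower number a stronger inhibitor:
- compound 1 `CC(NC(=O)CCc1ccc(NC(=O)Nc2ccc(Cl)c(C(F)(F)F)c2)cc1)c1ccccc1`: > 50000 nM (a limit)
- compound 2 `O=C(CCc1ccc(NC(=O)Nc2ccc(Cl)c(C(F)(F)F)c2)cc1)NC1CCC1`: > 50000 nM (a limit)
- compound 3 `CNC(=O)CCc1ccc(NC(=O)Nc2ccc(Cl)c(C(F)(F)F)c2)cc1`: 24000 nM

For the measured compounds named here, compound 3 holds the only true number in the set, and its reading is the lowest. The other two compounds sit at the limit of > 50000 nM in this assay, at which 2 of the 3 values shown sit.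

Compound 4 `CC1CN(C(=O)CCc2ccc(NC(=O)Nc3ccc(Cl)c(C(F)(F)F)c3)cc2)CC(C)O1` differs from compound 3 in one place, on a carbonyl carbon: 2,6-dimethylmorpholin-4-yl in place of methylamino on a carbonyl carbon.

Going by the values given here, two measured steps bear on this change: an at least 2.0-fold lower number from compound 1 to compound 3 (0.31 log units; beyond the scatter) and an at least 2.0-fold lower number from compound 2 to compound 3 (0.31 log units; beyond the scatter). Both put methyl in place of another group on an amide-type nitrogen, so read in reverse they suggest that losing methyl raises the number. Their size is known only as a bound, and a step that the two limits leave unreadable from compound 1 to compound 2. Neither compound 1 nor compound 2 carries the 2,6-dimethylmorpholin-4-yl group, so the parallel is loose.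

In this assay a modest rise is therefore expected, and the estimated move is a 2.1-fold higher number from compound 3 to compound 4 (0.32 log units; beyond the scatter). Compound 4 is estimated at 50000 nM, with an expected range from 18000 nM to 120000 nM.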

Compound 4, half-maximal inhibitory concentration: > 50000 nM
Compound 4 ended at the assay's limit; the forecaster's own chance of this, stated with the estimate: 60%; the middle value lies on the limit itself.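

In this assay, 2,6-dimethylmorpholin-4-yl in place of methylamino gives an at least 2.0-fold higher number from compound 3 to compound 4 (0.31 log units; beyond the scatter), a step known only as a bound, since compound 4 reads at a limit of the assay. Compound 4 is the first compound shown whose group on the carbonyl carbon has 0 hydrogen-bond donors, so the high reading now appears both with the amide hydrogen kept, in compound 1 and compound 2, and with it gone, in compound 4; the steps from those two compounds to compound 4 cannot be read, as both ends are limits. Among the four compounds, only methylamino leaves a true number on the scale: the limit of > 50000 nM in this assay, at which 3 of the 4 values shown sit.

Going by these compounds, how far compound 1, compound 2 and compound 4 lie past the limit remains unknown. Also open, on these data alone, is whether a dimethylamino group, a plain primary amide or a carboxylic acid on the same carbonyl carbon would read lower than compound 3.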